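Series notes: ethyl to hydrogen on the ring amide nitrogen

The source may hold more compounds than are shown below. What is called first, only, known or untested is meant among the compounds shown, and "the series" means these compounds.

Compound 1 `N#CC1=C(N)Oc2cc3oc(-c4ccccc4)cc(=O)c3c(O)c2C12C(=O)N(Cc1ccccc1)c1ccc(Br)cc12` gives only a limit of the assay in a functional assay on PC-3 cells (Homo sapiens) for antiproliferative activity, read by MTT assay, with a stated time of 48 h (a lower number here means a stronger inhibitor, a higher number a weaker inhibitor), namely > 50000 nM.
Compound 2 `CCN1C(=O)C2(C(C#N)=C(N)Oc3cc4oc(-c5ccccc5)cc(=O)c4c(O)c32)c2cc(C)ccc21` likewise gives only a limit in this assay, namely > 50000 nM.

Both values shown are limits, not numbers, so compound 2 stands together with compound 1 at the limit of > 50000 nM in this assay, at which 2 of the 2 values shown sit, and no number separates the two. Compound 3 `Cc1ccc2c(c1)C1(C(=O)N2)C(C#N)=C(N)Oc2cc3oc(-c4ccccc4)cc(=O)c3c(O)c21` differs from compound 2 by hydrogen in place of ethyl on an amide-type nitrogen in a ring. Among the compounds with values here, no step between measured compounds is available. With both measured values sitting at the limit, no step beyond the scatter is expected from compound 2 to compound 3 in this assay. Compound 3 is expected to give about 60000 nM, with a range of 20000 nM to 300000 nM, and most probably again only a limit. The expected step that the limit leaves unreadable from compound 2 to compound 3 is thus none beyond the scatter.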

Compound 3, half-maximal inhibitory concentration: > 50000 nM
Compound 3 gave a limit, no number; the forecaster's own chance of this, stated with the estimate: 85%; the middle value lies beyond the limit too.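

Compound 2 and compound 3 both give only a limit in this assay, so no step can be read between them: the limit of > 50000 nM in this assay, at which 3 of the 3 values shown sit.

The compounds shown leave open whether hydrogen in place of ethyl on the ring amide nitrogen changes activity at all, since none gives a number.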